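This account rests on a few compounds, and the source may have more. Where it says the series, first, only, none or still open, it means among the compounds named here.

In an assay on isolated protein for binding affinity to fibroblast growth factor 1 (Homo sapiens), read by surface plasmon resonance (on this read-out lower numbers stand for tighter binding and higher numbers for weaker binding), compound 1 `CCN(CC(=O)NC[C@H]1O[C@H](OC)[C@@H](OS(=O)(=O)O)[C@@H](OS(=O)(=O)O)[C@@H]1OS(=O)(=O)O)C(=O)CCCCC(=O)O` gives 160000 nM, the second highest of the three numbers seen so far. Compound 2 `CO[C@H]1O[C@H](CNC(=O)CN(C(C)=O)c2ccccc2)[C@@H](OS(=O)(=O)O)[C@H](OS(=O)(=O)O)[C@@H]1OS(=O)(=O)O` gives 196000 nM in this assay, and compound 3 `CO[C@H]1O[C@H](CNC(=O)CN(CCOS(=O)(=O)O)C(C)=O)[C@@H](OS(=O)(=O)O)[C@H](OS(=O)(=O)O)[C@@H]1OS(=O)(=O)O` gives 95000 nM. The step of a 1.2-fold higher number from compound 1 to compound 2 (0.09 log units; within the scatter) and the step of a 1.7-fold lower number from compound 1 to compound 3 (0.23 log units; within the scatter) both stay within the scatter, while the step of a 2.1-fold lower number from compound 2 to compound 3 (0.31 log units; beyond the scatter) is a modest one.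

Compound 4 `CO[C@H]1O[C@H](CNC(=O)CN(C(C)=O)C2CCCCCC2)[C@@H](OS(=O)(=O)O)[C@H](OS(=O)(=O)O)[C@@H]1OS(=O)(=O)O` differs from compound 1 in one place: acetyl(cycloheptyl)amino in place of ((4-carboxybutyl)carbonyl)(ethyl)amino on a saturated chain carbon bound to a carbonyl carbon. The two measured steps that touch the same position, the step from compound 1 to compound 2 and the step from compound 1 to compound 3, bear on this change, and both stayed within the scatter; compound 2 carries the closest analogue of the entering group and sits within the scatter of compound 1. No step beyond the scatter in this assay is therefore expected from the change to the acetyl(cycloheptyl)amino group. Compound 4 is expected to give about 170000 nM in this assay, between 80000 nM and 360000 nM, which means an expected step of a 1.1-fold higher number from compound 1 to compound 4 (0.03 log units; within the scatter).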

Compound 4, dissociation constant: 370000 nM
Compound 4: the middle estimate sits 2.2-fold (0.34 log units) below what was measured; measured number outside the range, above it.
By their numbers in this assay, from the lowest: compounds 3, 1, 2 and 4 (each within the scatter of the next, the first and the last beyond it).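

In this assay, acetyl(cycloheptyl)amino on a saturated chain carbon bound to a carbonyl carbon gives the first step from compound 1 that lies beyond the scatter (a 2.3-fold higher number from compound 1 to compound 4 (0.36 log units; beyond the scatter)), whereas the earlier replacements there stayed within it. On the amide-type nitrogen, cycloheptyl in place of 2-(sulfooxy)ethyl gives a larger step (a 3.9-fold higher number from compound 3 to compound 4 (0.59 log units; beyond the scatter)), while cycloheptyl in place of phenyl stays within the scatter (a 1.9-fold higher number from compound 2 to compound 4 (0.28 log units; within the scatter)), so the saturated ring and the aromatic ring cannot be told apart here. No evidence is available to explain this result.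

The compounds shown leave open whether a cyclopentyl or cyclohexyl ring on the amide-type nitrogen would fall with cycloheptyl and phenyl. They also leave open whether a carboxylic acid or an amine on the cycloheptyl ring would move the number towards that of compound 3.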